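A few compounds are considered here, and "the series" means these few. Any claim that something is new, unique, unknown or untested is made for them only; others in the source may bear on it.

Compound 3 `Nc1nc(O)c2c(n1)n(C1OC(CO)[C@@H](O)[C@H]1O)c(=O)n2CCN1CCCCC1` carries a (piperidin-1-yl)methyl group on a saturated chain carbon bound to an aromatic nitrogen. In a functional assay on the whole organism (B cells) with Mus musculus as the target (on this read-out higher numbers stand for larger maximal responses and lower numbers for smaller maximal responses), compound 3 gives 0%, the lowest of the three measured numbers. Compound 1 `COc1ccc(Cn2c(=O)n(C3OC(CO)[C@@H](O)[C@H]3O)c3nc(N)nc(O)c32)cc1` gives 44% and compound 2 `N#Cc1cccc(Cn2c(=O)n(C3OC(CO)[C@@H](O)[C@H]3O)c3nc(N)nc(O)c32)c1` gives 16%. Compound 4 `N#Cc1ccc(Cn2c(=O)n(C3OC(CO)[C@@H](O)[C@H]3O)c3nc(N)nc(O)c32)cc1` differs from compound 3 in one place: 4-cyanophenyl in place of (piperidin-1-yl)methyl on a saturated chain carbon bound to an aromatic nitrogen. Within the data shown here, two measured steps bear on this change. Replacing 4-methoxyphenyl with (piperidin-1-yl)methyl gave a number 44 percentage points lower from compound 1 to compound 3 (beyond the scatter), and replacing 3-cyanophenyl with the same group gave a number 16 percentage points lower from compound 2 to compound 3 (beyond the scatter). Compound 4 reverses the second of these, with 4-cyanophenyl rather than 3-cyanophenyl, so an upward step of modest size is expected. Compound 4 is therefore estimated to reach 20%, with a range from 5% to 40%, a step of a number 20 percentage points higher from compound 3 to compound 4 (beyond the scatter).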

Compound 4, largest response reached (reported as maximal response), in percent of the reference or control that the assay uses: 50%
Compound 4: the middle estimate sits 30 percentage points below what was measured, and the stated range ends below it.
By their numbers in this assay, from the lowest: compound 3; then compound 2; then compounds 1 and 4 (each within the scatter of the next).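

In this assay the swap of 3-cyanophenyl for 4-cyanophenyl gives a number 34 percentage points higher from compound 2 to compound 4 (beyond the scatter) and so where the nitrile sits on the phenyl group matters, not merely that it is present. Replacing (piperidin-1-yl)methyl with 4-cyanophenyl gives a number 50 percentage points higher from compound 3 to compound 4 (beyond the scatter) while cyano in place of methoxy gives a number 6 percentage points higher from compound 1 to compound 4 (within the scatter) and so these two phenyl substituents are not told apart here. Nothing available explains these differences. Still open, going by these compounds, is how an amine or a carboxylic acid on that same phenyl carbon would behave, and whether a longer chain to the phenyl group keeps the response.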